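The compounds below may be only part of what the source reports. "The series", "measured", "known", "first", "only" and "open" are said of these compounds alone.

Measured compounds:
compound 1, `CCN(CCCCn1sc2cc(OC)c(OC)cc2c1=O)Cc1ccccc1`: in an assay on isolated protein for inhibition of Amine oxidase [flavin-containing] B (Homo sapiens), read by fluorescence, with a stated time of 30 min (a higher number here means a weaker inhibitor, a lower number a stronger inhibitor), compound 1 gives 20100 nM
compound 2, `CCN(CCCCn1sc2cc(OC)c(OC)cc2c1=O)Cc1ccc(N(C)C)cc1`: compound 2 gives 18800 nM
compound 3, `CCN(CCCCCCn1sc2cc(OC)c(OC)cc2c1=O)Cc1ccccc1`: compound 3 gives 20100 nM

Compound 1 and compound 2 share a core and differ by dimethylamino in place of hydrogen on an aromatic carbon; this change gave a 1.1-fold lower number from compound 1 to compound 2 (0.03 log units; within the scatter). Compound 3 has a different core from compound 1, and the difference between the two cores is not broken down here. Compound 4, `CCN(CCCCCCn1sc2cc(OC)c(OC)cc2c1=O)Cc1ccccc1N(C)C`, has not yet been tested; it differs from compound 3 by dimethylamino in place of hydrogen on an aromatic carbon. This is the same kind of change as from compound 1 to compound 2, though not the same: there the group sits para to a large group, here ortho to a large group. Compound 3 is expected to move to compound 4 by a 1.1-fold lower number from compound 3 to compound 4 (0.02 log units; within the scatter), resting on the small step seen from compound 1 to compound 2. Compound 4 is therefore estimated at 19000 nM, between 9000 nM and 40000 nM.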

Compound 4, half-maximal inhibitory concentration: 19600 nM
Compound 4: middle estimate off by 1.0-fold (0.01 log units), on the low side, within the range that was stated.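

The new step is a 1.0-fold lower number from compound 3 to compound 4 (0.01 log units; within the scatter) in this assay, for dimethylamino in place of hydrogen on an aromatic carbon. Set beside the earlier step, the change gives the same result on both cores, with neither step beyond the scatter: the same change on two cores in this assay, a 1.1-fold lower number (0.03 log units; within the scatter) from compound 1 to compound 2 and a 1.0-fold lower number (0.01 log units; within the scatter) from compound 3 to compound 4, 1.0-fold (0.02 log units) apart, within the scatter of two such steps This shows only that the change has no readable effect on these two cores, with the group ortho to a large group in compound 4 and placed differently in compound 2; it does not show that the same would hold on other cores, or why the number stays put.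

Still open, going by these compounds, is whether a different group on this aromatic ring, such as a carboxylic acid or a nitrile, would move the number beyond the scatter. Also open, on these data alone, is whether such a group would behave alike on both cores.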